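The source may hold more compounds than are shown below. What is called first, only, known or untested is meant among the compounds shown, and "the series" means these compounds.

Measured so far in a functional assay on PC-3 cells (Homo sapiens) for cytotoxicity, read by MTT assay, with a stated time of 48 h; a lower number here means a stronger inhibitor, a higher number a weaker inhibitor:
compound 1 `CC1=NN(C(=O)CCc2ccccc2)C(c2cc(Br)ccc2O)C1` gives 16300 nM
compound 2 `CC1=NN(C(=O)COc2ccc(Cl)cc2)C(c2cc(Br)cc(Br)c2O)C1` gives 40200 nM
compound 3 `Cc1ccc(C(=O)N2N=C(c3cc4ccccc4oc3=O)CC2c2ccccc2)cc1` gives 13200 nM

Compound 3 has the lowest of the three numbers. The nearest is compound 1, whose number lies within the usual scatter, so no order between the two can be read; compound 2 stands beyond the scatter with the higher number. All three are weak in this assay.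

Compound 4 `CC1CCCN(CC(=O)N2N=C(c3cc4ccccc4oc3=O)CC2c2ccccc2)C1` is next to be measured in this assay. It differs from compound 3 by (3-methylpiperidin-1-yl)methyl in place of 4-methylphenyl on a carbonyl carbon. Among the measured compounds shown here, no step between measured compounds is available to size this change; the three measured compounds, with quite different cores and acyl groups, all sit in the same weak range. A modest step at most is expected, in either direction, likely within the scatter. Compound 4 is expected to give 15000 nM, with a range from 5000 nM to 45000 nM. This is expected to be a step of a 1.1-fold higher number from compound 3 to compound 4 (0.06 log units; within the scatter).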

Compound 4, half-maximal inhibitory concentration: 28300 nM
Compound 4: the middle estimate sits 1.9-fold (0.28 log units) below what was measured; low and high end bracket the measured number.
By their numbers in this assay, from the lowest: compounds 3, 1, 4 and 2 (each within the scatter of the next, the first and the last beyond it).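

Among the compounds shown here, on the carbonyl carbon, (3-methylpiperidin-1-yl)methyl in place of 4-methylphenyl gives a 2.1-fold higher number from compound 3 to compound 4 (0.33 log units; beyond the scatter) in this assay, the first step that can be sized. The acyl group on this core therefore moves the number, but only modestly, and the non-aromatic ring with its nitrogen does not improve on 4-methylphenyl. No measured evidence bears on the reason for this step.

From the compounds shown here alone, it remains open whether the loss of the aromatic ring or the entry of the nitrogen carries the step. A cyclohexylmethyl group on the same carbonyl carbon would separate the two.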